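Chloro-to-hydrogen steps and cytotoxic tolerance in the series

A few compounds are considered here, and "the series" means these few. Any claim that something is new, unique, unknown or untested is made for them only; others in the source may bear on it.

Compound 1 `Cc1ccc(C(=O)N/N=C/c2cc(Cl)cc(Cl)c2O)c(O)c1` gives 708000 nM in an ADME assay on cells (Mus musculus, strain BALB/C) for cytotoxicity, read by MTT assay, with a stated time of 24 h; a lower number here means that less compound is tolerated, a higher number that more compound is tolerated. Compound 3 `Cc1ccc(C(=O)N/N=C/c2cc(Cl)ccc2O)c(O)c1` carries the change hydrogen in place of chloro on an aromatic carbon relative to compound 1; in this assay compound 3 gives 560000 nM, the step being a 1.3-fold lower number from compound 1 to compound 3 (0.10 log units; within the scatter). Compound 2 `Cc1ccc(C(=O)N/N=C/c2ccc(Cl)cc2Cl)c(O)c1` gives 291000 nM in this assay; the difference between the core of compound 2 and the core of compound 1 is not broken down here. Compound 4 `Cc1ccc(C(=O)N/N=C/c2ccc(Cl)cc2)c(O)c1` is not yet measured and differs from compound 2 by hydrogen in place of chloro on an aromatic carbon. This is the same kind of change as that from compound 1 to compound 3, not the same: here the place is ortho to a large group and meta to a chloro group, there it was ortho to a hydroxy group, meta to a chloro group and meta to a large group. By analogy with a 1.3-fold lower number from compound 1 to compound 3 (0.10 log units; within the scatter), the expected step in this assay is a 1.2-fold lower number from compound 2 to compound 4 (0.07 log units; within the scatter), within the scatter. Compound 4 is estimated at 250000 nM, likely between 120000 nM and 520000 nM.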

Compound 4, half-maximal cytotoxic concentration: 116000 nM
Beside the measured number, compound 4's estimate is 2.2-fold (0.33 log units) above it; the measured number lies below the stated range.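

Hydrogen in place of chloro on an aromatic carbon gives, in this assay, a 2.5-fold lower number from compound 2 to compound 4 (0.40 log units; beyond the scatter). Set beside the step on the core of compound 1, this step cannot be told apart from it, so the two pairs give no sign that the change behaves differently from one core to the other: the same change on two cores in this assay, a 1.3-fold lower number (0.10 log units; within the scatter) from compound 1 to compound 3 and a 2.5-fold lower number (0.40 log units; beyond the scatter) from compound 2 to compound 4, 2.0-fold (0.30 log units) apart, within the scatter of two such steps

Two pairs do not establish that the step has one size on both cores, and the chloro group does not leave the same place in each pair.

Still open, as far as these compounds go, is whether another group on that aromatic carbon, such as a methoxy group or an amine, would shift the number in this assay as hydrogen does.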